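From Methyl to Ethyl on the Core of Compound 2

A few compounds are considered here, and "the series" means these few. Any claim that something is new, unique, unknown or untested is made for them only; others in the source may bear on it.

Compound 1 `c1ccc2oc(Cn3ccnc3)cc2c1`: in a functional assay on HL-60 cells (Homo sapiens) for cytotoxicity, read by MTT assay, with a stated time of 48 h (on this read-out lower numbers stand for stronger inhibition and higher numbers for weaker inhibition), compound 1 gives only a limit, > 40000 nM.
Compound 2 `Cc1nccn1Cc1cc2ccccc2o1`: in this assay compound 2 gives only a limit, > 40000 nM.

Both measured compounds stand at the edge of what this assay can report. The step from compound 1 to compound 2, a step that the two limits leave unreadable from compound 1 to compound 2, cannot be read, because both values sit at the limit of > 40000 nM in this assay, at which 2 of the 2 values shown sit. Compound 2 therefore stands on no number at all, only on a limit.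

Compound 3 `CCc1nccn1Cc1cc2ccccc2o1` differs from compound 2 by methyl in place of hydrogen on a saturated chain carbon bound to an aromatic carbon, which, cut one bond further out, reads methyl to ethyl. Among the measured compounds shown here, the only measured step that touches this part of the core is the one from compound 1 to compound 2, and its size is not readable, so no direction beyond the scatter can be drawn from it. For compound 3 an inhibitory concentration of 60000 nM in this assay is expected, with a range from 20000 nM to 200000 nM. The step from compound 2 to compound 3 is expected to be a step that the limit leaves unreadable from compound 2 to compound 3.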

Compound 3, half-maximal inhibitory concentration: > 40000 nM
Compound 3: a limit, no number; the forecaster's own chance of this, stated with the estimate: 85%; the middle value is on the limit's open side.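

No new step can be read from compound 3: its steps from compound 1 and from compound 2 stay unreadable, because all three compounds stop at the same limit: the limit of > 40000 nM in this assay, at which 3 of the 3 values shown sit. As far as these compounds go, how strongly these compounds act on the cells, and whether hydrogen, methyl or ethyl on this part of the core makes any difference, remains open.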